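Two Weak Inhibitors and a Hydroxyphenyl Analogue

A few compounds are considered here, and "the series" means these few. Any claim that something is new, unique, unknown or untested is made for them only; others in the source may bear on it.

Measured compounds and their values:
Compound 1 `COc1cc(N2C(=O)[C@@H](Oc3ccccc3)[C@H]2c2ccc(Br)cc2)cc(OC)c1OC` gives 48000 nM in a functional assay on MCF7 cells (Homo sapiens) for antiproliferative activity, read by MTT assay, with stated times of 24 h and 72 h; a higher number here means a weaker inhibitor, a lower number a stronger inhibitor.
Compound 2 `COc1cc(N2C(=O)[C@@H](Oc3ccccc3)[C@H]2c2ccc([N+](=O)[O-])cc2)cc(OC)c1OC` gives 63000 nM in this assay.

Both compounds are weak inhibitors, and compound 2 gives the highest of the two numbers, though the step of a 1.3-fold higher number from compound 1 to compound 2 (0.12 log units; within the scatter) is within the scatter, so the two cannot be told apart. Among the measured compounds shown here, that single step, nitro in place of bromo on an aromatic carbon, is the only comparison available.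

Compound 3 `COc1cc(N2C(=O)[C@@H](Oc3ccccc3)[C@H]2c2cccc(O)c2)cc(OC)c1OC` is not yet measured. It differs from compound 2 by 3-hydroxyphenyl in place of 4-nitrophenyl on a saturated ring carbon. For the measured compounds named here, no measured step involves a hydroxy group, so the only guide is the one step from compound 1 to compound 2, which changed nothing beyond the scatter when one aromatic substituent replaced another on the shared core. On that basis the number for compound 3 is expected to stay close to that of compound 2, with a step of a 1.3-fold lower number from compound 2 to compound 3 (0.10 log units; within the scatter) that is expected to lie within the scatter.

The estimate for compound 3 is 50000 nM, with a range from 20000 nM to 130000 nM.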

Compound 3, half-maximal inhibitory concentration: 54000 nM
For compound 3 the middle estimate is 1.1-fold (0.03 log units) below the measured one; the measured number falls inside the stated range.
By their numbers in this assay, from the lowest: compounds 1, 3 and 2 (each within the scatter of the next).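

Compound 3 changes more than the earlier step did: the substituent is now a hydroxy group rather than a nitro group, and it sits on a different ring carbon, as the names 3-hydroxyphenyl and 4-nitrophenyl show. It also brings a hydrogen-bond donor, which 4-nitrophenyl lacks, yet in this assay this swap gives a 1.2-fold lower number from compound 2 to compound 3 (0.07 log units; within the scatter), and replacing 4-bromophenyl gives a 1.1-fold higher number from compound 1 to compound 3 (0.05 log units; within the scatter), so all three compounds remain indistinguishable. This position on the four-membered ring has therefore now taken three different aryl groups with no change that can be read, although nothing measured here explains that outcome.

An amine or a carboxylic acid on this phenyl ring, or a longer alkyl chain in place of the whole ring, could still give a clearly different number, so the three compounds cannot show whether this position matters in general. All three also keep the phenoxy group and the rest of the shared core, which leaves open how a change in those parts would affect the number.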